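Swapping Bromo for Cyano on a Shared Core

This account rests on a few compounds, and the source may have more. Where it says the series, first, only, none or still open, it means among the compounds named here.

Among the measured compounds shown here, compound 2 `CC(C)n1nc(-c2ccc3oc(N)nc3c2)c2c(Br)nc(N)nc21` is one of two compounds measured in an ADME assay on cells (Hepatocyte, Homo sapiens) for metabolic stability, read by LC-MS, with a stated time of 90 min, tested at 1 uM; on this read-out higher numbers stand for fast clearance and lower numbers for slow clearance. In this assay compound 2 gives 55 uL/min. For the measured compounds named here, its only comparator is compound 1 `CC(C)n1nc(-c2ccc3oc(N)nc3c2)c2c(F)nc(N)nc21`, which gives 57 uL/min; the step of a 1.0-fold lower number from compound 1 to compound 2 (0.02 log units; within the scatter), bromo in place of fluoro on an aromatic carbon, left the number where it was. Compound 2 thus stands at the low end of these two numbers, but the gap between them lies within the scatter, so neither compound can be placed ahead of the other.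

Compound 3 `CC(C)n1nc(-c2ccc3oc(N)nc3c2)c2c(C#N)nc(N)nc21` has not yet been measured. It differs from compound 2 by cyano in place of bromo on an aromatic carbon. Going by the values given here, the single measured step at this position, a 1.0-fold lower number from compound 1 to compound 2 (0.02 log units; within the scatter), was flat. No cyano group has been measured here, so expecting another small step is an assumption. Compound 3 is therefore estimated to give 55 uL/min, within 30 uL/min to 100 uL/min, an expected step of no change at the digits printed from compound 2 to compound 3 (within the scatter).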

Compound 3, intrinsic clearance in a liver preparation (reported as CLH), per the amount of preparation that the assay uses: < 5 uL/min
Compound 3: a limit, no number (the forecaster's own chance of this, stated with the estimate: 5%); middle value at least 11-fold (1.04 log units) from the limit.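

Cyano in place of bromo gives an at least 11-fold lower number from compound 2 to compound 3 (1.04 log units; beyond the scatter), and cyano in place of fluoro gives an at least 11-fold lower number from compound 1 to compound 3 (1.05 log units; beyond the scatter), so this position, flat in the swap between fluoro and bromo, can carry a large change in this assay. The value of compound 3, < 5 uL/min, is a limit of the assay and not a number. Compound 3 alone stands at that limit: the limit of < 5 uL/min in this assay, at which 1 of the 3 values shown sits.

The compounds shown leave open whether such a large step belongs to cyano alone or would also come with another group at this position, such as a methyl, an amine or a carboxamide. They also offer no cause for the step, and with a single shared core they cannot tell whether cyano would do the same on a different one.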